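The compounds below may be only part of what the source reports. "The series", "measured", "known", "first", "only" and "open" are said of these compounds alone.

The measured compounds and their values:

compound 1, `COc1cc(C)cc(-c2c(-c3ccnc(-c4ccc(C(C)=O)cc4)c3)cnn2CC#N)c1`: -9%
compound 2, `COc1cc(C)cc(-c2nn(CC#N)cc2-c2ccc(-c3cccc(C(C)=O)c3)nc2)c1`: -27%
compound 3, `Cc1cc(O)cc(-c2nn(CC#N)cc2-c2ccnc(-c3ccc(Oc4ccccc4)cc3)c2)c1`: -79%

In a functional assay on NCI-H460 cells (Homo sapiens) for cytotoxicity, read by sulforhodamine B assay, with a stated time of 48 h, tested at 1 uM (a higher number here means a weaker effect of the compound at the concentration tested, a lower number a stronger effect), compound 1 gives -9%, the highest of the three numbers, which means the weakest effect of the set at the concentration tested. Compound 2 lies below it, beyond the scatter, and compound 3 lies furthest below it, also beyond the scatter. For the measured compounds named here, no pair of these three compounds differs in one place only, so none of these gaps can be tied to a single structural change.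

Compound 4, `COc1cc(C)cc(-c2c(-c3ccnc(-c4ccc(N(C)C)cc4)c3)cnn2CC#N)c1`, is not yet measured in this assay. It differs from compound 1 in one place: dimethylamino in place of acetyl on an aromatic carbon. Going by the values given here, there is no measured pair showing this change, so its effect on the read-out is unknown; the estimate rests on the value of compound 1 alone. The step expected from this change, a number 6 percentage points lower from compound 1 to compound 4 (within the scatter), is small, pointing toward a somewhat lower number, and may well stay within the scatter. For compound 4 the expected value in this assay is -15%, with a range from -45% to 10%.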

Compound 4, a percentage reported as activity, at one concentration (the size of the read-out at that concentration, not a potency): -53%
The estimate for compound 4 lay 38 percentage points above the measured number; the measured number lies below the stated range.
By their numbers in this assay, from the lowest: compound 3; then compound 4; then compound 2; then compound 1.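

In this assay, for the compounds shown here, the change from 4-acetylphenyl to 4-(dimethylamino)phenyl gives a number 44 percentage points lower from compound 1 to compound 4 (beyond the scatter), and this is the first gap in the set that can be tied to a single structural change. It shows that this place on the aromatic ring, para to a large group, is not indifferent to what it carries: the read-out moves well beyond the scatter even though the two groups match in heavy-atom count, in hydrogen-bond donors and acceptors, and in having no ring and no net charge, and differ in the carbonyl double bond and in oxygen giving way to nitrogen. No evidence is at hand that explains the size of this step.

Going by these compounds alone, the single pair leaves open whether the step follows from the loss of acetyl or from the entry of dimethylamino, and whether a primary amine, a methoxy group or a carboxylic acid at the same place would read closer to compound 1 or to compound 4. It also leaves open whether dimethylamino in place of acetyl would give a step of like size in compound 2, which carries an acetyl as well.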